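Ethyl to Methylcyclopropyl on the Amide Carbonyl

The source may hold more compounds than are shown below. What is called first, only, known or untested is meant among the compounds shown, and "the series" means these compounds.

Compound 1 `CC(=O)N1CC2CC(C1)N2` and compound 2 `CCC(=O)N1CC2CC(C1)N2` share the same bicyclic core and differ only in the chain attached to the carbonyl carbon. In an assay on SH-EP1 cells for agonist activity at Neuronal acetylcholine receptor; alpha4/beta2 (Homo sapiens), read by FLIPR and calcium flux (a higher number here means a larger maximal response, a lower number a smaller maximal response), compound 1 gives 95%. In this assay, among the measured compounds shown here, compound 2 gives 110%, the higher of the two numbers measured so far; its nearest neighbour is compound 1, and the step of a number 15 percentage points higher from compound 1 to compound 2 (beyond the scatter) is modest but lies beyond the usual scatter. Compound 3 `C[C@@H]1C[C@@H]1C(=O)N1CC2CC(C1)N2` has not yet been measured. Its change from compound 2 is a group of 4 heavy atoms (4 carbon; one three-membered non-aromatic ring of carbon only) in place of a group of 2 heavy atoms (2 carbon; no ring), on a carbonyl carbon. For the measured compounds named here, only one measured step bears on this change, the one from compound 1 to compound 2, where a chain grown by one carbon gave a modest rise. Growing the group further, now into a small ring, is a different kind of change, so only a small movement in either direction, or none beyond the scatter, is expected. Compound 3 is therefore expected to give 110% in this assay, with a range from 85% to 135%. The expected step of no change at the digits printed from compound 2 to compound 3 (within the scatter) is thus small and close to the scatter.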

Compound 3, largest response reached (Emax), in percent of the reference or control that the assay uses: 97%
Compound 3: the middle estimate sits 13 percentage points above what was measured; measured number inside the range.
By their numbers in this assay, from the lowest: compounds 1 and 3 (each within the scatter of the next); then compound 2.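

Lengthening the group on this carbonyl carbon does not keep raising the maximal response: in this assay, replacing ethyl with the group of 4 carbon atoms that holds a three-membered ring gives a number 13 percentage points lower from compound 2 to compound 3 (beyond the scatter) and so reverses the earlier gain. The larger group also fails to hold any of that gain, as the comparison with the smaller group of compound 1 gives a number 2 percentage points higher from compound 1 to compound 3 (within the scatter) and leaves those two compounds indistinguishable in this measurement, so compound 3 goes against any simple rule that a bigger group on this carbon gives a larger response. Of these three compounds, only compound 2 with its ethyl group stands clear of the others, and no measurement offered here explains why the response falls again with the ring-bearing group.

The compounds shown leave open whether the lower number goes with the ring itself, with the methyl group on it, or with its 2 defined stereocentres. A plain cyclopropyl group, an open propyl chain and the mirror-image form of the methylcyclopropyl group would each help to separate these possibilities.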